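The source may hold more compounds than are shown below. What is called first, only, known or untested is meant among the compounds shown, and "the series" means these compounds.

Compound 2 `COc1ncc(C(F)(F)F)cc1CO[C@H]1[C@H](C(C)(C)C)[C@@H](C(=O)O)N(C(=O)[C@@H]2CCCCO2)[C@H]1c1ccccc1Cl` gives the lower of the two numbers measured in an assay on cells with Cystic fibrosis transmembrane conductance regulator variant F508del (Homo sapiens) as the target, read by voltage clamp, with a stated time of 24 h, in the presence of a further agent that is not named here (a lower number here means a smaller maximal response, a higher number a larger maximal response), namely 694%; compound 1 `COc1ncc(C(F)(F)F)cc1CO[C@H]1[C@H](C(C)(C)C)[C@@H](C(=O)O)N(C(=O)[C@@H]2CCCCO2)[C@H]1c1ccccc1` gives 720%. For the measured compounds named here, the only measured step is a number 26 percentage points lower from compound 1 to compound 2 (beyond the scatter), a modest drop. Compound 3 `COc1ncc(C(F)(F)F)cc1CO[C@H]1[C@H](C(C)(C)C)[C@@H](C(=O)O)N(C(=O)[C@@H]2CCCCO2)[C@H]1c1ccccc1CC(C)C` differs from compound 2 by isobutyl in place of chloro on an aromatic carbon. Going by the values given here, no measured step exchanges chloro for isobutyl, so the one known step offers only weak guidance. A change of similar or smaller size is therefore expected, likely not beyond the scatter: the step from compound 2 to compound 3 is estimated as a number 14 percentage points lower from compound 2 to compound 3 (beyond the scatter). Compound 3 is expected to give about 680%, between 560% and 820%.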

Compound 3, largest response reached (Emax), in percent of the reference or control that the assay uses: 472%
Beside the measured number, compound 3's estimate is 208 percentage points above it; the whole stated range lies above it.
By their numbers in this assay, from the lowest: compound 3; then compound 2; then compound 1.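

Putting isobutyl on this aromatic carbon, ortho to a large group, gives a number 222 percentage points lower from compound 2 to compound 3 (beyond the scatter) and a number 248 percentage points lower from compound 1 to compound 3 (beyond the scatter) in this assay. The position therefore responds far more strongly to some groups than the chloro step alone showed, and the maximal response depends heavily on what sits there. No available evidence explains the drop.

The compounds shown leave open whether a shorter chain such as methyl or ethyl would give a smaller drop. They also leave open how an oxygen-containing group such as methoxy, or an amine, would behave here.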